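A pyridazine in place of a pyrimidine: solubility outlook

The source may hold more compounds than are shown below. What is called first, only, known or untested is meant among the compounds shown, and "the series" means these compounds.

Compound 1 `COc1ccc(Nc2cc3[nH]c(-c4cccc(C(F)(F)F)c4)nc3cn2)nc1` and compound 2 `FC(F)(F)c1cccc(-c2nc3cnc(Nc4ncccn4)cc3[nH]2)c1` share a core and differ only in the group on a nitrogen on an aromatic ring. In a physicochemical assay for solubility, using the shake flask method, in phosphate buffer, measured as kinetic solubility, with a stated time of 20 h, at pH 6.5 (on this read-out higher numbers stand for higher solubility and lower numbers for lower solubility), compound 1 gives < 5000 nM, which is a limit of the assay rather than a number. In this assay compound 2 likewise gives < 5000 nM, again a limit of the assay. The step that the two limits leave unreadable from compound 1 to compound 2 therefore cannot be sized, and the limit of < 5000 nM in this assay, at which 2 of the 2 values shown sit, sums up what the two readings show. Compound 3 `FC(F)(F)c1cccc(-c2nc3cnc(Nc4cccnn4)cc3[nH]2)c1` has not yet been measured in this assay. It differs from compound 2 by pyridazin-3-yl in place of pyrimidin-2-yl on a nitrogen on an aromatic ring. For the measured compounds named here, no measured step bears directly on this change; the single step available, from compound 1 to compound 2, is unreadable, so no direction beyond the scatter can be expected. Given that compound 2 sits at the limit in this assay, compound 3 is expected to read 3000 nM, with a range from 500 nM to 8000 nM, and most likely again as a limit. The step that the limit leaves unreadable from compound 2 to compound 3 is thus estimated to be small.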

Compound 3, solubility: < 5000 nM
Compound 3: no number, only a limit; the forecaster's own chance of this, stated with the estimate: 75%; the middle value is on the limit's open side.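

In this assay compound 3 gives < 5000 nM, which is a limit of the assay. Neither step to compound 3, from compound 1 or from compound 2, can be read, and the three readings come to one thing: the limit of < 5000 nM in this assay, at which 3 of the 3 values shown sit. From the compounds shown here alone, the actual solubility of compound 1, compound 2 and compound 3 stays open, as does whether exchanging the group on the nitrogen moves it at all.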